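The compounds below may be only part of what the source reports. "The series", "measured", "known", "first", "only" and "open" are said of these compounds alone.

Compound 1 `CCCCS(=O)(=O)Nc1cc(-c2ccc3ncnc(NCCN(C)C)c3c2)cnc1OC` gives the lower of the two numbers measured in a functional assay on HCT-116 cells (Homo sapiens) for antiproliferative activity, read by sulforhodamine B assay, with a stated time of 72 h (on this read-out lower numbers stand for stronger inhibition and higher numbers for weaker inhibition), where compound 1 shows 160 nM. Going by the values given here, its only measured neighbour is compound 2 `COc1ncc(-c2ccc3ncnc(NCCN(C)C)c3c2)cc1NS(C)(=O)=O`, which in this assay gives 13500 nM; the step of an 84-fold higher number from compound 1 to compound 2 (1.93 log units; beyond the scatter) arises from hydrogen in place of propyl on a saturated chain carbon bound to a sulfonyl sulfur. Compound 3 `CCCCS(=O)(=O)Nc1cc(-c2ccc3ncnc(NCCCN(C)C)c3c2)cnc1OC` has not yet been measured. It differs from compound 1 in a different part of the molecule: (dimethylamino)methyl in place of dimethylamino on a saturated chain carbon, two bonds along the chain from a nitrogen on an aromatic ring. Among the compounds with values here, no measured step touches this chain, so the step from compound 1 to compound 2 does not bear on it, and nothing in the data points to a change beyond the usual scatter. For compound 3 a step of a 1.3-fold higher number from compound 1 to compound 3 (0.10 log units; within the scatter) is expected in this assay. Compound 3 is therefore estimated at 200 nM, with a range from 70 nM to 600 nM.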

Compound 3, half-maximal inhibitory concentration: 490 nM
Estimate against measurement, compound 3: 2.5-fold (0.39 log units) below; low and high end bracket the measured number.
By their numbers in this assay, from the lowest: compound 1; then compound 3; then compound 2.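

In this assay the chain carrying the dimethylamino group proves sensitive to a small extension: (dimethylamino)methyl in place of dimethylamino, on a saturated chain carbon, two bonds along the chain from a nitrogen on an aromatic ring, gives a 3.1-fold higher number from compound 1 to compound 3 (0.49 log units; beyond the scatter). Going by these compounds alone, this is the first measured change at this position, and it is a modest one, much smaller than the other step, an 84-fold higher number from compound 1 to compound 2 (1.93 log units; beyond the scatter). No evidence available here explains why the added carbon raises the number.

The compounds shown leave open whether a still longer chain, such as 4-(dimethylamino)butyl, would raise the number further, and whether a morpholine or pyrrolidine could replace the dimethylamino group at the chain end. They also leave open whether the same extension would have a similar effect with the methyl group of compound 2 on the sulfonyl sulfur.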